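A few compounds are considered here, and "the series" means these few. Any claim that something is new, unique, unknown or untested is made for them only; others in the source may bear on it.

Within the data shown here, compound 1 `CCCC(=O)OCCCCOC(=O)c1ccc(C(=O)Nc2ccc3c(c2)C(C)(C)CCC3(C)C)cc1` is the one compound here with a measured number in a functional assay on NB-4 cells (Homo sapiens) for inhibition, read by MTT assay, with a stated time of 48 h (a lower number here means a stronger inhibitor, a higher number a weaker inhibitor), and compound 1 gives 23200 nM. Compound 2 `C=C(c1ccc(C(=O)OCCOC(=O)c2ccc(C(=O)Nc3ccc4c(c3)C(C)(C)CCC4(C)C)cc2)cc1)c1cc2c(cc1C)C(C)(C)CCC2(C)C` was tested as well, but in this assay compound 2 gave > 1000000 nM, which is a limit of the assay rather than a number, as recorded in the limit of > 1000000 nM in this assay, at which 1 of the 2 values shown sits. So compound 1 stands as the single value that can be compared. Compound 3 `CCCC(=O)OCCCOC(=O)c1ccc(C(=O)Nc2ccc3c(c2)C(C)(C)CCC3(C)C)cc1` has not yet been measured. It differs from compound 1 in one place: (propylcarbonyl)oxy in place of ((propylcarbonyl)oxy)methyl on a saturated chain carbon, three bonds along the chain from an oxygen next to a carbonyl group. Among the measured compounds shown here, no step between two measured compounds is available here, so nothing shows how far such a change moves the result. Only the linker chain changes while every other part of compound 1 stays, so a small step, none beyond the scatter, is expected: a 1.1-fold lower number from compound 1 to compound 3 (0.02 log units; within the scatter). Compound 3 is therefore estimated at 22000 nM in this assay, within a range from 7000 nM to 70000 nM.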

Compound 3, half-maximal inhibitory concentration: 5750 nM
The estimate for compound 3 lay 3.8-fold (0.58 log units) above the measured number; the whole stated range lies above it.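

In this assay, going from 4-((propylcarbonyl)oxy)butyl to 3-((propylcarbonyl)oxy)propyl gives a 4.0-fold lower number from compound 1 to compound 3 (0.61 log units; beyond the scatter). This is the first pair shown that differs in one place, and it shows that this saturated chain position is not neutral: changing the chain length alone, with the shared core and the propylcarbonyl ester kept, moves the result beyond the scatter. Nothing measured here explains why the shorter chain gives the lower number.

With only these two chain lengths compared, one step cannot show whether the number keeps falling with a still shorter 2-((propylcarbonyl)oxy)ethyl chain or rises again with a longer chain. On these data alone, it also remains open how an amine or a carboxylic acid at the end of the chain, in place of the propylcarbonyl ester, would behave.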